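From compound 1 to compound 3: chloro for methyl

The source may report more compounds than this note shows. Statements on the series, on what has been measured and on what is new or still open speak of the compounds shown alone.

Compound 1 (`Cc1cc(NC(=O)Nc2ccc(C)c(Cl)c2)c2ccccc2n1`) is the starting point of this step. In an ADME assay on Raji cells (Homo sapiens) for cytotoxicity, with a stated time of 72 h (a higher number here means that more compound is needed for the effect, a lower number that less compound is needed), compound 1 gives > 25000 nM, which is a limit of the assay and not a number. Compound 2 (`Cc1cc(NC(=O)Nc2ccccc2OC(F)(F)F)c2ccccc2n1`) gives > 25000 nM, which is likewise a limit. Neither compound therefore has an exact place on the scale.

Compound 3 (`Cc1cc(NC(=O)Nc2ccc(Cl)c(Cl)c2)c2ccccc2n1`) carries chloro in place of methyl on an aromatic carbon, ortho to a chloro group and para to a large group (chloro in place of methyl on an aromatic carbon). Among the measured compounds shown here, no step between measured compounds shows what a single change does in this assay, so the evidence is thin. The expectation rests on compound 1 and compound 2 sharing (the limit of > 25000 nM in this assay, at which 2 of the 2 values shown sit). On that ground, no step beyond the usual scatter is expected, and a further limit is the likeliest report for compound 3. The estimated outcome is a number no higher from compound 1 to compound 3 (the limit leaves the size open). The expected half-maximal effective concentration of compound 3 is 25000 nM, with an estimated range of 12000 nM to 40000 nM.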

Compound 3, half-maximal effective concentration: 10000 nM
The estimate for compound 3 lay 2.5-fold (0.40 log units) above the measured number; measured number outside the range, below it.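

In this assay, chloro in place of methyl on an aromatic carbon, ortho to a chloro group and para to a large group, gives an at least 2.5-fold lower number from compound 1 to compound 3 (0.39 log units; beyond the scatter), so a single change at this position can move the read-out beyond the scatter. Compound 1 gives > 25000 nM, which is a limit of the assay and not a number. Compound 3 is the only compound shown that has come off this limit, and it gives the series its first exact value, a fixed point against which further changes at this position can be read: the limit of > 25000 nM in this assay, at which 2 of the 3 values shown sit.

From the compounds shown here alone, the step has only a lower bound on its size, so how far the number truly falls from compound 1 to compound 3 remains open, and a single pair cannot show whether the loss of methyl or the arrival of chloro matters more. Also open, going by these compounds, is how this position would respond to a methoxy group, an amine, a nitrile or a longer chain, and whether any of these would lie nearer to compound 3 or to compound 1 in this assay.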